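This account rests on a few compounds, and the source may have more. Where it says the series, first, only, none or still open, it means among the compounds named here.

Compound 2 `CCC(Sc1nc2c(cnn2C)c(=O)n1-c1ccccc1)c1ccccc1` is the starting point here. In an assay on isolated protein for inhibition of retinal dehydrogenase 2 (Homo sapiens) (a higher number here means a weaker inhibitor, a lower number a stronger inhibitor), compound 2 gives 179 nM, the lowest number among the three compounds measured, although its gap to compound 3 is too small to count as a real difference. Compound 3 `CC(C)C(Sc1nc2c(cnn2C)c(=O)n1-c1ccccc1)c1ccccc1` gives 300 nM in this assay, and compound 1 `C#Cc1ccc(-n2c(SC(C)c3ccccc3)nc3c(cnn3C)c2=O)cc1`, which carries a different group on the phenyl ring of the shared core, gives 800 nM, a gap from compound 2 that does lie beyond the scatter.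

Compound 4 `C[C@@H](Sc1nc2c(cnn2C)c(=O)n1-c1ccccc1)c1ccccc1` has not yet been measured. It differs from compound 2 in one place: 1-phenylethyl in place of 1-phenylpropyl on a sulfur. Among the measured compounds shown here, the one measured step that bears on this change is the one in this assay from compound 2 to compound 3, a 1.7-fold higher number from compound 2 to compound 3 (0.22 log units; within the scatter), where a methyl was added on the same chain; that step stayed within the scatter. Shortening the chain by one carbon is expected to behave alike, so no step beyond the scatter is expected, a 1.2-fold higher number from compound 2 to compound 4 (0.09 log units; within the scatter). Compound 4 is therefore estimated at 220 nM, within a range from 100 nM to 480 nM.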

Compound 4, half-maximal inhibitory concentration: 40 nM
For compound 4 the middle estimate is 5.5-fold (0.74 log units) above the measured one, and the stated range ends above it.
By their numbers in this assay, from the lowest: compound 4; then compounds 2 and 3 (each within the scatter of the next); then compound 1.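

In this assay, the group on the sulfur proves able to shift the number well beyond the scatter (a 4.5-fold lower number from compound 2 to compound 4 (0.65 log units; beyond the scatter)), which the earlier step on this chain (a 1.7-fold higher number from compound 2 to compound 3 (0.22 log units; within the scatter)) did not show. The change from 1-phenylpropyl to 1-phenylethyl is one carbon shorter and also brings a defined stereocentre, so this single step cannot separate the effect of chain length from that of the stereocentre. No measurement at hand explains why the number falls.

As far as these compounds go, it remains open how the mirror-image form of compound 4 would compare, which would isolate the part played by the stereocentre. From the compounds shown here alone, it is also open whether a benzyl group on the sulfur, or an amine on the chain, would keep a number this low.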